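This account rests on a few compounds, and the source may have more. Where it says the series, first, only, none or still open, it means among the compounds named here.

For the measured compounds named here, in an assay on isolated protein for binding affinity to corticotropin-releasing factor receptor 1 (Homo sapiens) (on this read-out higher numbers stand for weaker inhibition and lower numbers for stronger inhibition), compound 2 `CC(=O)/C(=N\c1ccccc1)NNc1ccccc1C(F)(F)F` gives 2260 nM, the higher of the two numbers so far; compound 1 `CC(=O)/C(=N\c1ccccc1)NNc1ccccc1C` gives 526 nM in this assay. Going by the values given here, the only measured step, a 4.3-fold higher number from compound 1 to compound 2 (0.63 log units; beyond the scatter), involves a trifluoromethyl in place of a methyl on an aromatic carbon. Compound 3 `CC(=O)/C(=N\c1ccccc1)NNc1ccccc1C#N` carries cyano in place of trifluoromethyl on an aromatic carbon. Among the compounds with values here, no measured step covers a cyano group, so the single step from compound 1 to compound 2 is the only guide, and it points to a change of modest size at most. Compound 3 is therefore expected to sit near compound 2 in this assay, with a step of a 1.7-fold lower number from compound 2 to compound 3 (0.24 log units; within the scatter) expected, and an estimated value of 1300 nM (range 400 nM to 4000 nM).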

Compound 3, inhibition constant: 1080 nM
The estimate for compound 3 lay 1.2-fold (0.08 log units) above the measured number; low and high end bracket the measured number.
By their numbers in this assay, from the lowest: compound 1; then compound 3; then compound 2.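

In this assay, cyano in place of trifluoromethyl gives a 2.1-fold lower number from compound 2 to compound 3 (0.32 log units; beyond the scatter), so the higher number of compound 2 is not shared by every replacement of methyl at this position. Cyano in place of methyl still gives a 2.1-fold higher number from compound 1 to compound 3 (0.31 log units; beyond the scatter), which leaves methyl with the lowest number of the three groups on this aromatic carbon, and both steps lie beyond the scatter. Nothing available explains this order. The compounds shown leave open whether an amine, a methoxy group or a plain hydrogen here would give a number lower than that of compound 1. They also leave open whether a longer chain would be tolerated at this position.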